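The source may report more compounds than this note shows. Statements on the series, on what has been measured and on what is new or still open speak of the compounds shown alone.

In a functional assay on PC-3 cells (Homo sapiens) for antiproliferative activity, read by MTT assay, with a stated time of 72 h (a higher number here means a weaker inhibitor, a lower number a stronger inhibitor), the two measured compounds read as follows.

Compound 1 `CCn1cc(C(CC)(CC)c2ccc(C#CC(O)(CC)CC)c(C)c2)cc1C(=O)NCCCN(C)C`: 15100 nM
Compound 2 `CCn1cc(C(CC)(CC)c2ccc(C#CC(O)(CC)CC)c(C)c2)cc1C(=O)OCCO`: 11400 nM

Compound 2 stands level with compound 1, and neither can be ranked above the other. Among the compounds with values here, the one measured step is a 1.3-fold lower number from compound 1 to compound 2 (0.12 log units; within the scatter) and it changes the group on the same carbonyl carbon that matters next. Compound 3 `CCCCC(=O)c1cc(C(CC)(CC)c2ccc(C#CC(O)(CC)CC)c(C)c2)cn1CC` carries butyl in place of 2-hydroxyethoxy on a carbonyl carbon and has not yet been measured. Within the data shown here, no measured compound carries butyl, so that single small step is thin evidence. In this assay no shift beyond the scatter is therefore expected, in either direction. The expected size is a 1.1-fold lower number from compound 2 to compound 3 (0.06 log units; within the scatter) on this estimate. For compound 3 the estimated value is 10000 nM within an expected range of 3500 nM to 25000 nM for now.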

Compound 3, half-maximal inhibitory concentration: 48100 nM
Estimate against measurement, compound 3: 4.8-fold (0.68 log units) below, outside the stated range (above it).
By their numbers in this assay, from the lowest: compounds 2 and 1 (each within the scatter of the next); then compound 3.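

In this assay, the group on this carbonyl carbon proves able to move the number beyond the scatter, which the earlier pair did not show: butyl gives a 4.2-fold higher number from compound 2 to compound 3 (0.63 log units; beyond the scatter) when it replaces 2-hydroxyethoxy, and a 3.2-fold higher number from compound 1 to compound 3 (0.50 log units; beyond the scatter) when it replaces (3-(dimethylamino)propyl)amino. Butyl and 2-hydroxyethoxy each count 4 heavy atoms, so this step changes the atoms and the hydrogen-bond donors and acceptors at the position, not the heavy-atom count. Nothing available here accounts for the rise.

The compounds shown leave open whether a hydroxyl at the end of the butyl chain would bring the number back to the level of compound 2. They also leave open how a carboxylic acid, a shorter alkyl chain such as methyl, or a longer alkyl chain would read on this carbonyl carbon.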